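The source may hold more compounds than are shown below. What is called first, only, known or untested is meant among the compounds shown, and "the series" means these compounds.

Compound 1, `COc1cc(CNC2CCCCC2)ccc1OCc1ccc(Cl)nc1`, stands without a single number: in a functional assay on HeLa cells (Homo sapiens) for inhibition, with a stated time of 72 h (on this read-out lower numbers stand for an effect already at smaller amounts and higher numbers for an effect only at larger amounts of compound), compound 1 is recorded only as "nd(insoluble)" (no result reported). Two further compounds from the same series carry numbers. Within the data shown here, compound 2, `COc1cc(CNCc2ccncc2)ccc1OCc1ccc(Cl)c(Cl)c1`, gives 4000 nM in this assay, and compound 3, `CCOc1cc(CNCc2ccncc2)ccc1OCc1ccc(Cl)cc1`, gives 2500 nM in this assay; these two values lie close to each other, and no step between them is computed here. The account now follows the change from compound 1 to compound 4, `COc1cc(CNCc2cccs2)ccc1OCc1ccc(Cl)nc1`, which is not yet measured. The difference between the two structures is (thiophen-2-yl)methyl in place of cyclohexyl on an amine nitrogen. Among the measured compounds shown here, since compound 1 has no number, no step between measured compounds is available for this change, and the expectation for compound 4 rests only on compound 2 and compound 3, whose values in this assay point to the low-micromolar region for amines of this kind. No shift beyond the usual scatter in either direction is expected from this change. Compound 4 is therefore estimated to give about 3000 nM in this assay, with a range from 800 nM to 12000 nM.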

Compound 4, half-maximal effective concentration: 96000 nM
For compound 4 the middle estimate is 32-fold (1.51 log units) below the measured one; measured number outside the range, above it.
By their numbers in this assay, from the lowest: compounds 3 and 2 (each within the scatter of the next); then compound 4.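

In this assay, among these compounds, compound 1 has no number, so no step to compound 4 can be read. The compounds shown leave open what (thiophen-2-yl)methyl in place of cyclohexyl does on its own. No measured evidence bears on this result.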